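The source may hold more compounds than are shown below. What is called first, only, known or untested is meant among the compounds shown, and "the series" means these compounds.

Working notes on the series.

Two compounds of this series have been run in a functional assay on PC-3 cells (Homo sapiens) for cytotoxicity, read by MTT assay, with a stated time of 72 h; on this read-out higher numbers stand for weaker inhibition and lower numbers for stronger inhibition. Compound 1 `Cc1ccc(-c2ccnc(C(=O)Nc3ccc(Oc4ccnc5[nH]ccc45)c(F)c3)n2)cc1` gives 520 nM in this assay. For the measured compounds named here, compound 2 `O=C(Nc1ccc(Oc2ccnc3[nH]ccc23)c(F)c1)c1nccc(-c2cccc(Cl)c2)n1` gives 1380 nM in this assay, the highest of the two numbers; the nearest is compound 1, and the one step measured so far, a 2.7-fold higher number from compound 1 to compound 2 (0.42 log units; beyond the scatter), is the only comparison available.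

Compound 3 `O=C(Nc1ccc(Oc2ccnc3[nH]ccc23)c(F)c1)c1nccc(-c2ccc([N+](=O)[O-])cc2)n1` has not yet been measured in this assay. Its change from compound 2 is 4-nitrophenyl in place of 3-chlorophenyl on an aromatic carbon. Going by the values given here, only one measured step bears on it: a 2.7-fold higher number from compound 1 to compound 2 (0.42 log units; beyond the scatter), which also exchanged the aryl group at this position and moved the number by a modest amount. Nothing measured addresses a 4-nitrophenyl group, so no direction can be taken from the data. The expected step in this assay is therefore none beyond the scatter, with wide uncertainty on either side, giving an expected change of a 1.1-fold higher number from compound 2 to compound 3 (0.04 log units; within the scatter). For compound 3 the estimated value in this assay is 1500 nM, with a range from 450 nM to 5000 nM.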

Compound 3, half-maximal inhibitory concentration: 12100 nM
The estimate for compound 3 lay 8.1-fold (0.91 log units) below the measured number; the measured number lies above the stated range.
By their numbers in this assay, from the lowest: compound 1; then compound 2; then compound 3.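

In this assay the aryl group at this position turns out to be much less forgiving than the first exchange suggested: 4-nitrophenyl in place of 3-chlorophenyl gives an 8.8-fold higher number from compound 2 to compound 3 (0.94 log units; beyond the scatter), against a 2.7-fold higher number from compound 1 to compound 2 (0.42 log units; beyond the scatter) for the earlier exchange. The cleanest reading comes from the pair that keeps the phenyl ring and its substitution place, where nitro in place of methyl gives a 23-fold higher number from compound 1 to compound 3 (1.37 log units; beyond the scatter), so one substituent on this ring is enough to shift the number by a large amount. No measurement at hand bears on what lies behind this rise.

The step from compound 2 to compound 3 changes both the substituent and its place on the ring, so the compounds shown do not separate the effect of the nitro group from the effect of where it sits. A 4-chlorophenyl group would address that split, while an unsubstituted phenyl and a 4-aminophenyl group at the same carbon would show whether the high number of compound 3 is specific to nitro.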